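Methyl for methoxy on a second core: buffer half-life

A few compounds are considered here, and "the series" means these few. Any claim that something is new, unique, unknown or untested is made for them only; others in the source may bear on it.

Measured so far in an ADME assay for pharmacokinetics, in phosphate buffer, tested at 60 uM; on this read-out higher numbers stand for a longer-lived compound and lower numbers for a shorter-lived compound:
compound 1 `COc1ccc(NC(=S)OCCNC(=O)C(C)(C)Oc2ccc(Cl)cc2)cc1` gives 0.015 h
compound 2 `COc1ccc(NC(=S)OCCNC(=O)c2cccnc2)cc1` gives 0.0133 h
compound 3 `Cc1ccc(NC(=S)OCCNC(=O)C(C)(C)Oc2ccc(Cl)cc2)cc1` gives 0.0167 h

Compound 1 and compound 3 share one core and differ by methyl in place of methoxy on an aromatic carbon. In this assay that change made a 1.1-fold higher number from compound 1 to compound 3 (0.05 log units; within the scatter), so nothing beyond repeat scatter separates the two. Compound 2 carries a second core; the difference between the two cores is not broken down here. Its number is the lowest of the three, but its gaps to compound 1 and to compound 3 both lie within the scatter, so no order among the three compounds is established.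

Compound 4 `Cc1ccc(NC(=S)OCCNC(=O)c2cccnc2)cc1` has not been measured. It differs from compound 2 by methyl in place of methoxy on an aromatic carbon, the same change, at the same kind of place, as that from compound 1 to compound 3. For the measured compounds named here, on the one precedent, the step is expected to be small: a 1.1-fold higher number from compound 2 to compound 4 (0.05 log units; within the scatter) is estimated, resting on a 1.1-fold higher number from compound 1 to compound 3 (0.05 log units; within the scatter) in this assay. For compound 4 the estimate in this assay is 0.015 h, expected between 0.008 h and 0.028 h.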

Compound 4, half-life: 0.015 h
Compound 4: middle estimate and measured number agree at the digits printed; the range from low to high includes it.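

In this assay, methyl in place of methoxy on an aromatic carbon gives a 1.1-fold higher number from compound 2 to compound 4 (0.05 log units; within the scatter). Set beside the earlier step, the change reads the same on the two cores: the same change on two cores in this assay, a 1.1-fold higher number (0.05 log units; within the scatter) from compound 1 to compound 3 and a 1.1-fold higher number (0.05 log units; within the scatter) from compound 2 to compound 4, 1.0-fold (0.01 log units) apart, within the scatter of two such steps

The two pairs therefore show no sign that the core alters this step, but both steps lie within the scatter, so there is no measurable effect here to carry from one core to the other, and agreement between two small steps says nothing about a third core or about a larger step.

Still open, on these data alone, is whether any other group on that aromatic carbon, such as an amine or a carboxylic acid, would separate from methyl and methoxy in half-life by more than the scatter. Also open, as far as these compounds go, is whether a longer chain between the aromatic ring and the amide would shift the half-life on either core, and whether the methyl and methoxy pairs would then still agree.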